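The compounds below may be only part of what the source reports. "The series", "measured", "known", "first", "only" and "open" are said of these compounds alone.

Measured compounds:
Compound 1, `COc1ccc(/C=C/C(=O)c2ccc(NC(=O)C(C)O[N+](=O)[O-])cc2)cc1`, gives 46% in a functional assay on the whole organism (strain albino) for inhibition, with Rattus norvegicus as the target, read by paw edema, with stated times of 30 min and 2 h, at a dose of 100 mg/kg by the oral route; a higher number here means more inhibition at the dose given (going by the name of the read-out), a lower number less inhibition.
Compound 2, `CC(O[N+](=O)[O-])C(=O)Nc1ccc(C(=O)/C=C/c2ccco2)cc1`, gives 48% in this assay.
Compound 3, `COc1ccc(/C=C/C(=O)c2ccc(NC(=O)COc3ccc(/C(C)=N\O)cc3)cc2)cc1`, gives 41% in this assay.

Compounds 1 and 2 share a core and differ in one place: furan-2-yl in place of 4-methoxyphenyl on a double-bonded chain carbon bound to a double-bonded chain carbon. In this assay this change made a step of a number 2 percentage points higher from compound 1 to compound 2 (within the scatter), so the two numbers show no difference that the read-out can separate. Compound 3 sits on a different core; how the core of compound 3 differs from the core of compound 1 is not broken down here. Its value is the lowest of the three, but its gaps to compound 1 and to compound 2 both lie within the scatter, so no order among the three can be claimed.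

Compound 4, `C/C(=N/O)c1ccc(OCC(=O)Nc2ccc(C(=O)/C=C/c3ccco3)cc2)cc1`, has not yet been measured. It differs from compound 3 in one place: furan-2-yl in place of 4-methoxyphenyl on a double-bonded chain carbon bound to a double-bonded chain carbon. Within the data shown here, the place is described in the same words for both pairs, so this is the same change as the one from compound 1 to compound 2, made here on the core of compound 3. Because the earlier step was only a number 2 percentage points higher from compound 1 to compound 2 (within the scatter), compound 4 is expected to land close to compound 3, with an estimated step of a number 2 percentage points higher from compound 3 to compound 4 (within the scatter). Whether the same step carries over to the other core is not shown by any measured pair. For compound 4 the estimated value in this assay is 43%, with an expected range from 33% to 53%.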

Compound 4, a percentage reported as inhibition, in the whole organism at one dose (the size of the read-out at that dose, not a potency): 44%
The estimate for compound 4 lay 1 percentage points below the measured number; low and high end bracket the measured number.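

Made on the core of compound 3, the replacement of 4-methoxyphenyl by furan-2-yl gave in this assay a step of a number 3 percentage points higher from compound 3 to compound 4 (within the scatter), so the read-out does not separate these two compounds. Set beside the earlier step on the core of compound 1, the new step agrees with it: the same change on two cores in this assay, a number 2 percentage points higher (within the scatter) from compound 1 to compound 2 and a number 3 percentage points higher (within the scatter) from compound 3 to compound 4, 1 percentage points apart, within the scatter of two such steps. This shows that the change left the number within the scatter on both cores, but it does not show that the change has a real effect that carries from one core to the other, since a change with no readable effect on either core would give the same picture, and two pairs say nothing about any further core.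

The compounds shown leave open whether a different group in this place, such as thiophen-2-yl or a phenyl ring carrying an amine or a carboxylic acid, would move the number beyond the scatter on either core. They also leave open whether the two members of each pair would stay this close at another dose or at another time of reading.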